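The compounds below may be only part of what the source reports. "The series", "measured", "known", "first", "only" and "open" are said of these compounds alone.

Measured compounds:
compound 1 `CCOC(=O)c1csc2nc(CN3CCN(Cc4ccccc4)CC3)c(-c3ccc(C)cc3)n12`, > 100000 nM;
compound 2 `CCOC(=O)c1csc2nc(CN3CCN(Cc4ccccc4)CC3)c(-c3ccc(OC)cc3)n12`, 29400 nM;
compound 3 `CC(=O)NNC(=O)c1csc2ncc(-c3ccc(C)cc3)n12`, 92700 nM.

The three compounds were tested in a functional assay on PC-3 cells (Homo sapiens) for antiproliferative activity, read by MTT assay, with a stated time of 72 h; a lower number here means a stronger inhibitor, a higher number a weaker inhibitor. For compound 1 the assay gave only a limit, > 100000 nM, and no number. Compound 2 gave 29400 nM, and compound 3 gave 92700 nM. The change from compound 1 to compound 2 is methoxy in place of methyl on an aromatic carbon, and it made an at least 3.4-fold lower number from compound 1 to compound 2 (0.53 log units; beyond the scatter). How far that step reaches is bounded by the limit of > 100000 nM in this assay, at which 1 of the 3 values shown sits. The difference between the core of compound 1 and the core of compound 3 is not broken down here.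

Compound 4 `COc1ccc(-c2cnc3scc(C(=O)NNC(C)=O)n23)cc1` has not yet been measured in this assay. It differs from compound 3 by methoxy in place of methyl on an aromatic carbon, the same change that took compound 1 to compound 2. On the strength of an at least 3.4-fold lower number from compound 1 to compound 2 (0.53 log units; beyond the scatter), compound 4 is expected to show a 3.4-fold lower number from compound 3 to compound 4 (0.54 log units; beyond the scatter), a step of similar size. Compound 4 is therefore estimated at 27000 nM, with a range from 9000 nM to 80000 nM.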

Compound 4, half-maximal inhibitory concentration: 28300 nM
The estimate for compound 4 lay 1.0-fold (0.02 log units) below the measured number, and the stated range covers the measured number.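

In this assay, methoxy in place of methyl on an aromatic carbon gave a 3.3-fold lower number from compound 3 to compound 4 (0.52 log units; beyond the scatter), so on the core of compound 3 the number fell in the same direction as on the core of compound 1, and the two steps can be set side by side: the same change on two cores in this assay, an at least 3.4-fold lower number (0.53 log units; beyond the scatter) from compound 1 to compound 2 and a 3.3-fold lower number (0.52 log units; beyond the scatter) from compound 3 to compound 4; the limit leaves it open whether they differ

For compound 1 the value is a limit, > 100000 nM, and not a number. The direction of the change therefore carried over between these two cores, but whether its size is the same on both cannot be read, and two cores say nothing about any third core in the series.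

The compounds shown leave open whether the lower number is particular to methoxy or would also come with ethoxy, a hydroxyl or a chlorine on the same aromatic carbon. They also leave open how the change would behave if a carboxylic acid or a primary amide stood in place of the ethyl ester of compound 1.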